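The source may hold more compounds than are shown below. What is called first, only, known or untested is meant among the compounds shown, and "the series" means these compounds.

In a functional assay on HeLa cells (Homo sapiens) for antiproliferative activity, read by MTT assay, with a stated time of 72 h (on this read-out higher numbers stand for weaker inhibition and lower numbers for stronger inhibition), the measured compounds are these:

Compound 1 `CC/C=C/C(=O)Nc1cccc(Oc2nc(Nc3ccn(C)n3)nc3c2CSCC3)c1` gives > 50000 nM as a limit of the assay, not a number.
Compound 2 `CC/C=C/C(=O)Nc1cccc(Oc2nc(Nc3cccc(OC)c3)nc3c2CSCC3)c1` gives 27200 nM in this read-out.
Compound 3 `C=CC(=O)Nc1cccc(Oc2nc(Nc3cccc(C#N)c3)nc3c2CSCC3)c1` gives 34900 nM in this read-out.

Compound 3, at 34900 nM here, and compound 2, at 27200 nM here, lie within the scatter of each other. Compound 4 `CC/C=C/C(=O)Nc1cccc(Oc2nc(Nc3cccc(C#N)c3)nc3c2CSCC3)c1` differs from compound 3 by having but-1-en-1-yl in place of vinyl on a carbonyl carbon.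

For the measured compounds named here, the only measured step, an at least 1.8-fold lower number from compound 1 to compound 2 (0.26 log units; that floor lies within the scatter), lies elsewhere, on a nitrogen on an aromatic ring, and so gives no size for a change at this carbonyl carbon. No shift beyond the scatter is expected, since compound 2, which already carries but-1-en-1-yl, gives 27200 nM in the same range. The expected change is a 1.0-fold higher number from compound 3 to compound 4 (0.01 log units; within the scatter) and is taken to stay within the scatter. A report of only a limit for compound 4 remains possible, given the limit of > 50000 nM in this assay, at which 1 of the 3 values shown sits, here. For compound 4 the estimate is 36000 nM, with an expected range from 20000 nM to 50000 nM in this assay.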

Compound 4, half-maximal inhibitory concentration: 31800 nM
Estimate against measurement, compound 4: 1.1-fold (0.05 log units) above; the measured number falls inside the stated range.
By their numbers in this assay, from the lowest: compounds 2, 4 and 3 (each within the scatter of the next). At a limit, above all of these: compound 1.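

In this assay the change on the carbonyl carbon now has a size, with a 1.1-fold lower number from compound 3 to compound 4 (0.04 log units; within the scatter) as the step, so but-1-en-1-yl and vinyl cannot be told apart on this 3-cyanophenyl compound. The step of a 1.2-fold higher number from compound 2 to compound 4 (0.07 log units; within the scatter) adds that cyano and methoxy on the aromatic carbon cannot be told apart either, with but-1-en-1-yl held in place. The step of an at least 1.5-fold lower number from compound 1 to compound 4 (0.19 log units; that floor lies within the scatter) gives only a floor, for compound 1 stands at a limit and not at a number: the limit of > 50000 nM in this assay, at which 1 of the 4 values shown sits.

As far as these compounds go, what stays open is whether another group on this carbonyl carbon, such as a longer chain or a chain ending in an amine, would give a number beyond the scatter of these values. Also open, from the compounds shown here alone, is whether a carboxylic acid in place of cyano on the aromatic carbon would do so.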